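The compounds below may be only part of what the source reports. "The series", "measured", "known", "first", "only" and "open" are said of these compounds alone.

Working notes on the series.

Compound 1 `COc1ccc(-n2nncc2CN2C(=O)C3(C(C#N)=C(N)Oc4c3c3nc5ccccc5nc3c3ccccc43)c3ccccc32)cc1`, compound 2 `N#CC1=C(N)Oc2c(c3nc4ccccc4nc3c3ccccc23)C12C(=O)N(Cc1cnnn1-c1ccc(Cl)c(Cl)c1)c1ccccc12` and compound 3 `N#CC1=C(N)Oc2c(N)cc3nc4ccccc4nc3c2C12C(=O)N(Cc1cnnn1-c1cccc(Br)c1)c1ccccc12` share one core and differ only in the aryl group on the aromatic nitrogen. In an ADME assay on L02 cells (Homo sapiens) for antiproliferative activity, read by MTT assay, with a stated time of 48 h (on this read-out lower numbers stand for stronger inhibition and higher numbers for weaker inhibition), compound 1 gives only a limit, > 50000 nM. In this assay compound 2 likewise gives only a limit, > 50000 nM. In this assay compound 3 also gives only a limit, > 50000 nM. Among the compounds with values here, the one step between measured compounds that differ in a single place, a step that the two limits leave unreadable from compound 1 to compound 2, is therefore unreadable, and all three values sit at the limit of > 50000 nM in this assay, at which 3 of the 3 values shown sit, so compound 3 stands at the same limit as the other two and no ordering among them can be stated.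

Compound 4 `N#CC1=C(N)Oc2c(N)cc3nc4ccccc4nc3c2C12C(=O)N(Cc1cnnn1-c1c(F)cccc1F)c1ccccc12` is not yet measured. It differs from compound 3 by 2,6-difluorophenyl in place of 3-bromophenyl on an aromatic nitrogen. Within the data shown here, no measured step bears directly on this change; the only step, from a 4-methoxyphenyl to a 3,4-dichlorophenyl on the same nitrogen, has no readable size. Given that every aryl variation so far has stayed at the limit, compound 4 is expected to stay there as well, with an expected step that the limit leaves unreadable from compound 3 to compound 4 not resolvable from the limit. The estimate for compound 4 in this assay is 60000 nM, within 30000 nM to 150000 nM.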

Compound 4, half-maximal inhibitory concentration: > 50000 nM
Compound 4 was reported as a limit; the forecaster's own chance of this, stated with the estimate: 85%; the middle value is on the limit's open side.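

Within the data shown here, compound 3 and compound 4 both give only a limit in this assay and no step between the two can be read, so the series stays where it stood: the limit of > 50000 nM in this assay, at which 4 of the 4 values shown sit. The compounds shown leave open how far each lies past that limit and whether any aryl group on this aromatic nitrogen gives a readable value in this assay at all.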